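The source may hold more compounds than are shown below. What is called first, only, known or untested is meant among the compounds shown, and "the series" means these compounds.

In an ADME assay on HEK293-A cells (Homo sapiens) for cytotoxicity, read by MTT assay, with a stated time of 48 h (on this read-out lower numbers stand for stronger inhibition and higher numbers for weaker inhibition), compound 1 `O=C1CCC(=O)N1C[C@H]1CN(c2ccc(-n3cc(-c4ccccn4)cn3)c(F)c2)C(=O)O1` gives > 400 ug/mL, which is a limit and not a number. Compound 2 `O=C1CNC(=O)N1C[C@H]1CN(c2ccc(-n3cc(-c4ccccn4)cn3)c(F)c2)C(=O)O1` gives > 400 ug/mL, also a limit. Compound 3 `O=C(OC[C@H]1CN(c2ccc(-n3cc(-c4ccccn4)cn3)c(F)c2)C(=O)O1)c1ccccc1` gives > 400 ug/mL, again a limit. Compound 3 therefore has no numerical position in the series, and the measured compounds all stand at the limit of > 400 ug/mL in this assay, at which 3 of the 3 values shown sit.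

Compound 4 `CS(=O)(=O)NC[C@H]1CN(c2ccc(-n3cc(-c4ccccn4)cn3)c(F)c2)C(=O)O1` is the next compound, with one change from compound 3: methanesulfonamido in place of benzoyloxy on a saturated chain carbon bound to a saturated ring carbon.

Going by the values given here, three measured steps concern this same place on the chain: a step that the two limits leave unreadable from compound 1 to compound 2, a step that the two limits leave unreadable from compound 1 to compound 3 and a step that the two limits leave unreadable from compound 2 to compound 3. Among the compounds with values here, none of them has a readable size or direction, but no compound among the three goes against the shared limit. On that basis, no step beyond the scatter is expected in this assay, and no direction can be assigned. The expected change is a step that the limit leaves unreadable from compound 3 to compound 4. For compound 4 the estimated value is 500 ug/mL, with an expected range of 250 ug/mL to 1000 ug/mL. A result reported only as a limit is the likeliest expectation.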

Compound 4, half-maximal inhibitory concentration: 314 ug/mL
The estimate for compound 4 lay 1.6-fold (0.20 log units) above the measured number, within the range that was stated.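

In this assay, going by these compounds alone, compound 4 gives 314 ug/mL, the first readable number at this place on the chain, so not every group at this place leaves the result without a number. Against the other compounds the result gives an at least 1.2-fold lower number from compound 3 to compound 4 (0.10 log units; that floor lies within the scatter), an at least 1.2-fold lower number from compound 2 to compound 4 (0.10 log units; that floor lies within the scatter) and an at least 1.2-fold lower number from compound 1 to compound 4 (0.10 log units; that floor lies within the scatter); each is only a floor within the scatter, so no real drop is established for methanesulfonamido over benzoyloxy, 2,5-dioxoimidazolidin-1-yl or 2,5-dioxopyrrolidin-1-yl. The steps among compound 1, compound 2 and compound 3 cannot be read, and these compounds stay together at a limit: the limit of > 400 ug/mL in this assay, at which 3 of the 4 values shown sit.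

As far as these compounds go, the true size of each step stays open, as does whether the readable number belongs to methanesulfonamido alone. A primary amine or ethanesulfonamido at this place would show whether a readable number recurs.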